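The source may hold more compounds than are shown below. What is called first, only, known or untested is meant among the compounds shown, and "the series" means these compounds.

Working notes on the series.

Compound 1 `CC(C)CCc1c(OCCCCCCCC(=O)NO)ccc2ccc(=O)oc12` and compound 2 `CC(C)CCc1c(OCCCCC(=O)NO)ccc2ccc(=O)oc12` share one core; compound 3 `CC(C)CCc1c(OCCCCC(=O)NO)ccc2c1OC(=O)CC2` and compound 4 `CC(C)CCc1c(OCCCCCCCC(=O)NO)ccc2c1OC(=O)CC2` share another. How the core of compound 2 and the core of compound 3 differ is not broken down here.

In a functional assay on PC-3 cells (Homo sapiens) for antiproliferative activity, read by sulforhodamine B assay, with a stated time of 48 h (a higher number here means a weaker inhibitor of growth, a lower number a stronger inhibitor of growth), compound 1 gives 1730 nM. In this assay compound 2 gives 1940 nM. The difference between them is 3-(hydroxycarbamoyl)propyl in place of hydroxycarbamoyl on a saturated chain carbon, four bonds along the chain from an oxygen on an aromatic ring, and the step is a 1.1-fold lower number from compound 2 to compound 1 (0.05 log units; within the scatter).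

For compound 3 the assay reports only a limit, > 30000 nM; this is the limit (the limit of > 30000 nM in this assay, at which 1 of the 3 values shown sits), not a number.

Compound 4 differs from compound 3 by the same change, (3-(hydroxycarbamoyl)propyl in place of hydroxycarbamoyl on a saturated chain carbon, four bonds along the chain from an oxygen on an aromatic ring). For the measured compounds named here, since the change made essentially no step from compound 2 to compound 1, as seen in a 1.1-fold lower number from compound 2 to compound 1 (0.05 log units; within the scatter), the expectation is that compound 4 will stay close to compound 3, which stands only at a limit; the expected step is a number no higher from compound 3 to compound 4 (the limit leaves the size open). The estimate for compound 4 in this assay is therefore 30000 nM, expected to fall between 8000 nM and 100000 nM, most likely again reported only as a limit.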

Compound 4, concentration for 50% growth inhibition: > 30000 nM
Compound 4: a limit, no number; the forecaster's own chance of this, stated with the estimate: 65%; the middle value lies on the limit itself.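

In this assay compound 4 gives > 30000 nM, a limit and not a number, and compound 3 also stands at a limit, so no step from compound 3 to compound 4 can be read: the limit of > 30000 nM in this assay, at which 2 of the 4 values shown sit.

The compounds shown leave open whether 3-(hydroxycarbamoyl)propyl in place of hydroxycarbamoyl changes growth inhibition at all on the core shared by compound 3 and compound 4.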